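A few compounds are considered here, and "the series" means these few. Any claim that something is new, unique, unknown or untested is made for them only; others in the source may bear on it.

Measured so far in an ADME assay for permeability, using PAMPA, with a stated time of 30 min, at pH 7.4; a lower number here means that the compound crosses the layer more slowly, a higher number that the compound crosses the layer faster:
Compound 1 `Cc1c(C)n(Cc2ccccc2)c2ncn(C3CCOCC3)c(=N)c12` gives 1680 10^-6 cm/s.
Compound 2 `N=c1c2c(-c3ccccc3)c(-c3ccccc3)n(CC3CCCCC3)c2ncn1CCCO` gives only a limit of this assay, > 1000 10^-6 cm/s.
Compound 3 `Cc1c(C)n(Cc2ccccc2)c2ncn(CCCO)c(=N)c12` gives 609 10^-6 cm/s.

Compound 3 thus sits lowest of the two plain numbers; its nearest neighbour is compound 1, and the step of a 2.8-fold lower number from compound 1 to compound 3 (0.44 log units; beyond the scatter) shows the drop that came with exchanging a ring for a chain. Compound 4 `Cc1c(C)n(Cc2ccccc2)c2ncn([C@H]3CC[C@H](O)CC3)c(=N)c12` reverses that kind of change: 4-hydroxycyclohexyl in place of 3-hydroxypropyl on an aromatic nitrogen. Going by the values given here, the only measured step that bears on it is the one from compound 1 to compound 3, a modest one, so a modest rise from compound 3 is expected for compound 4, roughly undoing that step; the expected step is a 1.8-fold higher number from compound 3 to compound 4 (0.26 log units; within the scatter). In this assay compound 4 is therefore estimated at 1100 10^-6 cm/s, within 550 10^-6 cm/s to 2200 10^-6 cm/s.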

Compound 4, apparent permeability: < 1 10^-6 cm/s
Compound 4 gave a limit, no number; the forecaster's own chance of this, stated with the estimate: 25%; at least 1100-fold (3.04 log units) between middle value and limit.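

In this assay, this position proves far more sensitive than the earlier step suggested: there is an at least 600-fold lower number from compound 3 to compound 4 (2.78 log units; beyond the scatter), and an at least 1600-fold lower number from compound 1 to compound 4 (3.22 log units; beyond the scatter). A six-membered ring here does not by itself keep the number high: compound 1 and compound 4 both carry one, yet they sit far apart. The reading for compound 4 is a limit, not a number: the limit of < 1 10^-6 cm/s in this assay, at which 1 of the 4 values shown sits.

From the compounds shown here alone, how far compound 4 really falls stays open. So does whether plain cyclohexyl, without the hydroxyl, or 4-aminocyclohexyl would land near compound 1 or near compound 4.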